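The source may report more compounds than this note shows. Statements on the series, on what has been measured and on what is new or still open speak of the compounds shown alone.

Working notes on the series: compound 1 `Cc1ccc(Cc2nnc(NC(=O)/C(C#N)=C/c3ccccc3OS(=O)(=O)c3ccc(C)cc3)s2)cc1` and compound 2 `Cc1ccc(Cc2nnc(NC(=O)/C(C#N)=C/c3ccccc3OS(=O)(=O)c3ccc([N+](=O)[O-])cc3)s2)cc1` share the same core and differ at one substituent. In an ADME assay on HEK-293T cells (Homo sapiens) for inhibition, read by CCK-8 assay, with a stated time of 48 h, tested at 20 uM (a higher number here means more inhibition of growth at the concentration tested, a lower number less inhibition of growth), compound 1 gives 22% and compound 2 gives 9%, so compound 2 holds the lower of the two numbers.

The next structure is compound 3 `Cc1ccc(Cc2nnc(NC(=O)/C(C#N)=C/c3ccccc3OS(=O)(=O)c3ccc(F)cc3)s2)cc1`, with fluoro in place of nitro on an aromatic carbon, para to a large group: fluoro in place of nitro on an aromatic carbon. This turns the (4-nitrophenyl)sulfonyl group into the (4-fluorophenyl)sulfonyl group.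

For the measured compounds named here, one measured step bears on this change: a number 13 percentage points lower from compound 1 to compound 2 (beyond the scatter). That step was modest and brought in the same nitro group that compound 3 gives up. Going by the values given here, two compounds define no trend, and no fluoro compound has yet been measured, so that step serves only as a rough guide to size. In this assay, a small upward move is expected, smaller than that step and possibly not beyond the scatter. The expected step is a number 6 percentage points higher from compound 2 to compound 3 (within the scatter). For compound 3 the estimated value is 15%, with an expected range of 4% to 29%.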

Compound 3, percent growth inhibition at one concentration: 11%
Beside the measured number, compound 3's estimate is 4 percentage points above it; the measured number falls inside the stated range.
By their numbers in this assay, from the lowest: compounds 2 and 3 (each within the scatter of the next); then compound 1.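

In this assay, fluoro in place of nitro on this aromatic carbon, para to a large group, gives a number 2 percentage points higher from compound 2 to compound 3 (within the scatter), so these two groups cannot be told apart at this position, despite what leaves and enters under this change. Fluoro in place of methyl gives a number 11 percentage points lower from compound 1 to compound 3 (beyond the scatter), which shows that the gap to compound 1 is not specific to the nitro group: among the three para substituents, compound 1 alone stands apart, with compound 2 and compound 3 together at the lower end of the growth-inhibition read-out. No measurement on these compounds accounts for the methyl compound standing apart from the other two.

From the compounds shown here alone, whether this split follows any wider rule stays open, since an amine, a methoxy group, a carboxylic acid or a longer chain such as ethyl at the same carbon could read with compound 1, with compound 2 and compound 3, or with neither. Going by these compounds, all three readings also come from a single concentration and a single time point, so it remains open whether the gap to compound 1 would hold across a range of concentrations.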